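Adding a nitro group to a weak hydroxamic acid

The source may hold more compounds than are shown below. What is called first, only, known or untested is meant among the compounds shown, and "the series" means these compounds.

- Compound 1 `Nc1ccccc1NC(=O)c1ccc(CNCc2nc(-c3ccc(F)cc3)no2)cc1` gives 3510 nM 
- Compound 2 `O=C(NO)c1ccc(CNCc2nc(-c3ccccc3)no2)cc1` gives 29300 nM 

In a functional assay on HCT-116 cells (Homo sapiens) for inhibition, read by MTT assay, with a stated time of 72 h (a lower number here means a stronger inhibitor, a higher number a weaker inhibitor), compound 2 has the higher of the two numbers, beyond the scatter of compound 1, and so is the weaker inhibitor of the pair. Compound 3 `O=C(NO)c1ccc(CNCc2nc(-c3ccc([N+](=O)[O-])cc3)no2)cc1` differs from compound 2 by nitro in place of hydrogen on an aromatic carbon with nitro in place of hydrogen on an aromatic carbon, turning phenyl into 4-nitrophenyl. For the measured compounds named here, no measured pair shows what this change does. The estimated step of a 1.5-fold lower number from compound 2 to compound 3 (0.17 log units; within the scatter) is expected to stay within the scatter. For compound 3 the expected value is 20000 nM with an estimated range from 6000 nM to 60000 nM in this assay.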

Compound 3, half-maximal inhibitory concentration: 21900 nM
Estimate against measurement, compound 3: 1.1-fold (0.04 log units) below; the range from low to high includes it.
By their numbers in this assay, from the lowest: compound 1; then compounds 3 and 2 (each within the scatter of the next).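

In this assay, for the compounds shown here, the first pair to test this position gives a 1.3-fold lower number from compound 2 to compound 3 (0.13 log units; within the scatter), so turning phenyl into 4-nitrophenyl leaves the hydroxamic acid without a change that can be told from the scatter. This carbon, para to a large group, therefore accepts nitro in place of hydrogen without a gain or loss that this pair can show. No data given here offer an explanation for this result.

From the compounds shown here alone, what an amine or a carboxylic acid on this same carbon would give remains open. Also open, going by these compounds, is whether nitro would behave alike on the core of compound 1.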